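The compounds below may be only part of what the source reports. "The series", "measured", "known", "first", "only" and "open" are said of these compounds alone.

Measured compounds:
- compound 1 `Cc1ccc(-c2c(C)nc(NS(=O)(=O)c3cccc4ccccc34)c(C)c2C(OC(C)(C)C)C(=O)O)cc1C`, in an ADME assay on MT4 cells (Homo sapiens) for cytotoxicity, read by MTT assay (on this read-out higher numbers stand for lower toxicity in this test and lower numbers for higher toxicity in this test), compound 1 gives 16000 nM
- compound 2 `Cc1nc(NC(=O)NC2CCCCC2)c(C)c(C(OC(C)(C)C)C(=O)O)c1-c1ccc2c(c1C)CCCO2`, in this assay compound 2 gives 11000 nM

Compound 2 carries the smaller of the two numbers in this assay, but its gap to compound 1 is within the usual scatter of repeated measurements, so the two compounds cannot be told apart on these data. The piece now follows the step from compound 2 to compound 3 `Cc1nc(NC(=O)NC2CCCCC2)c(C)c(C(OC(C)(C)C)C(=O)O)c1-c1ccc2c(c1)CCCO2`, which has not yet been measured. The change is a single small one: hydrogen in place of methyl on an aromatic carbon. Among the measured compounds shown here, no pair of measured compounds differs in just one place, so no measured step shows how such a change moves the read-out of this assay. On that basis nothing beyond the scatter is expected for compound 3: the removal of one carbon at the fused ring system is a minor change, and the estimated step of a 1.1-fold higher number from compound 2 to compound 3 (0.04 log units; within the scatter) is taken to stay within the usual scatter. For compound 3 in this assay the expected value is therefore 12000 nM, with a range from 5000 nM to 30000 nM.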

Compound 3, half-maximal cytotoxic concentration: 17000 nM
Compound 3: middle estimate off by 1.4-fold (0.15 log units), on the low side, within the range that was stated.
By their numbers in this assay, from the lowest: compounds 2, 1 and 3 (each within the scatter of the next).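

Among the compounds shown here, compound 2 and compound 3 form the first pair here that differs in one place only, so this position can now be read directly: with hydrogen in place of methyl on this aromatic carbon, ortho to a fused ring and ortho to a large group, this assay gives a 1.5-fold higher number from compound 2 to compound 3 (0.19 log units; within the scatter). The methyl group is the only difference between the two compounds, and a step of this size does not separate them, so this single pair gives no sign that the methyl group at this position matters for the read-out of this cell test. None of the information available offers an explanation for the size of this step.

Going by these compounds, with only methyl and hydrogen compared at this carbon, it remains open how the same test would read with a longer chain, a methoxy group or an amine in that place. On these data alone, it is also open whether hydrogen in place of methyl would give a similar step on a different compound, since this single pair shares one urea-bearing structure and says nothing about compounds built differently, such as compound 1.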